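Dimethylamino for methyl on a para substituent

A few compounds are considered here, and "the series" means these few. Any claim that something is new, unique, unknown or untested is made for them only; others in the source may bear on it.

Of the compounds shown here, three built on a shared core have been tested in an assay on RBL-1 cells with Polyunsaturated fatty acid 5-lipoxygenase (Rattus norvegicus) as the target; a higher number here means a weaker inhibitor, a lower number a stronger inhibitor. Compound 1 `C=CCc1ccc2ccccc2c1O` gives 56 nM, compound 2 `Cc1ccc(Cc2ccc3ccccc3c2O)cc1` gives 24 nM, and compound 3 `Cc1ccc(C)c2c(O)c(Cc3ccccc3)ccc12` gives 120 nM. Compound 2 shows the lowest number of the three, and its gaps to compound 1 and to compound 3 both lie beyond the usual scatter. The unmeasured compound 4 `CN(C)c1ccc(Cc2ccc3ccccc3c2O)cc1` differs from compound 2 in one place: dimethylamino in place of methyl on an aromatic carbon. Among the measured compounds shown here, no measured pair isolates a change of this kind, so the direction is open; the expected step of a 1.3-fold higher number from compound 2 to compound 4 (0.10 log units; within the scatter) is small, and no change beyond the scatter is assumed. Compound 4 is therefore estimated at 30 nM, within a range from 10 nM to 90 nM.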

Compound 4, half-maximal inhibitory concentration: 140 nM
Estimate against measurement, compound 4: 4.7-fold (0.67 log units) below; measured number above the stated range.
By their numbers in this assay, from the lowest: compound 2; then compound 1; then compounds 3 and 4 (each within the scatter of the next).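

In this assay, replacing methyl with dimethylamino on the aromatic carbon para to a large group gives a 5.8-fold higher number from compound 2 to compound 4 (0.77 log units; beyond the scatter) and so weakens inhibition. Among the compounds shown here, what sits at this position therefore matters, which the earlier compounds could not show, as no two of them formed a matched pair. No measurement here explains the loss. The compounds shown leave open whether a smaller amine, such as plain amino, or a carbon group such as isopropyl would behave at this position like methyl or like dimethylamino.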